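Working notes: from compound 2 toward compound 4

The source may report more compounds than this note shows. Statements on the series, on what has been measured and on what is new or still open speak of the compounds shown alone.

Three compounds have numbers in an assay on isolated protein with Bile acid receptor (Homo sapiens) as the target; a lower number here means that less compound is needed, a higher number that more compound is needed for the effect. Compound 1 `COC(=O)/C=C/c1cccc(N(Cc2ccc(/C=C/c3ccc(F)cc3)cc2)C(=O)NC(C)C)c1` gives 348 nM, compound 3 `COC(=O)/C=C/c1cccc(N(Cc2ccc(-c3cccc(OC(F)(F)F)c3)cc2)C(=O)C(C)C)c1` gives 247 nM, and compound 2 `COC(=O)/C=C/c1cccc(N(Cc2ccc(-c3ccc(F)c(F)c3)cc2)C(=O)C2CCCCC2)c1` gives 72 nM, the lowest of the three, with both gaps beyond the usual scatter. These three differ from one another in more than one place, so their numbers are compared only as they stand. Compound 4 `COC(=O)/C=C/c1cccc(N(Cc2ccc(-c3c(OC)cccc3OC)cc2)C(=O)C2CCCCC2)c1` is not yet measured; relative to compound 2 the change is 2,6-dimethoxyphenyl in place of 3,4-difluorophenyl on an aromatic carbon. Among the compounds with values here, no measured pair isolates this change, so only a moderate step is expected, more likely upward than downward. For compound 4 the estimate is 150 nM, with a range from 50 nM to 500 nM, meaning an expected step of a 2.1-fold higher number from compound 2 to compound 4 (0.32 log units; beyond the scatter).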

Compound 4, half-maximal effective concentration: 77 nM
Estimate against measurement, compound 4: 1.9-fold (0.29 log units) above; measured number inside the range.
By their numbers in this assay, from the lowest: compounds 2 and 4 (each within the scatter of the next); then compounds 3 and 1 (each within the scatter of the next).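

Within the data shown here, compound 2 and compound 4 give the only comparison that isolates one place: in this assay, 2,6-dimethoxyphenyl in place of 3,4-difluorophenyl gives a 1.1-fold higher number from compound 2 to compound 4 (0.03 log units; within the scatter). This position on the aromatic ring, para to a large group, therefore accepts a group carrying hydrogen-bond acceptors as readily as one carrying fluorine, with no change beyond the scatter. Nothing available here accounts for this result.

Still open, going by these compounds, is how a carboxylic acid or an amine on this phenyl would read. On these data alone, whether the same exchange holds on the core of compound 3 is also open.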